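Carbamoyl to (morpholin-4-yl)carbonyl on compound 1

This account rests on a few compounds, and the source may have more. Where it says the series, first, only, none or still open, it means among the compounds named here.

In a functional assay (strain AB) with Danio rerio as the target, read by microscopy, with a stated time of 1 h (a higher number here means that more compound is needed for the effect, a lower number that less compound is needed), compound 1 (`CCN1CCc2c(sc(NC(=O)Nc3ccc(Cl)cc3)c2C(N)=O)C1`) gives 3120 nM, the higher of the two numerical values in the series, and compound 2 (`NC(=O)c1c(NC(=O)Nc2ccc(Cl)cc2)sc2c1CCN(CC1CCC1)C2`) gives 1360 nM. Compound 3 (`CCN1CCc2c(sc(NC(=O)CN3CCCCC3)c2C(N)=O)C1`) is reported only as a limit, > 25000 nM.

Compound 4 (`CCN1CCc2c(sc(NC(=O)Nc3ccc(Cl)cc3)c2C(=O)N2CCOCC2)C1`) is not yet measured. It carries morpholin-4-yl in place of amino on a carbonyl carbon, turning carbamoyl into (morpholin-4-yl)carbonyl (morpholin-4-yl in place of amino on a carbonyl carbon).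

For the measured compounds named here, no measured step changes the carbamoyl, so the evidence is indirect. Cyclobutyl in place of methyl gives a modest 2.3-fold lower number from compound 1 to compound 2 (0.36 log units; beyond the scatter), but at a different place. Closer in kind, though also at a different place, is the exchange on a carbonyl carbon that gives an at least 8.0-fold higher number from compound 1 to compound 3 (0.90 log units; beyond the scatter), and on that guide a higher number is expected in this assay. The expected change is a 3.2-fold higher number from compound 1 to compound 4 (0.51 log units; beyond the scatter). For compound 4 the estimated value is 10000 nM, with an expected range of 2500 nM to 25000 nM.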

Compound 4, half-maximal effective concentration: > 25000 nM
Compound 4 gave a limit, no number; the forecaster's own chance of this, stated with the estimate: 40%; at least 2.5-fold (0.39 log units) between middle value and limit.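

In this assay, the carbamoyl is now shown to be a position where a single exchange matters: an at least 8.0-fold higher number from compound 1 to compound 4 (0.90 log units; beyond the scatter), with the rest of the structure unchanged. Compound 4 is reported as a limit and not a number, so this step gives only a minimum size: the limit of > 25000 nM in this assay, at which 2 of the 4 values shown sit. The earlier limit came from a change on a different carbonyl carbon, an at least 8.0-fold higher number from compound 1 to compound 3 (0.90 log units; beyond the scatter), and one exchange at the carbamoyl alone is now seen to reach the same limit.

From the compounds shown here alone, it remains open whether any group in place of amino on this carbonyl carbon keeps a measurable number, or whether the loss is specific to morpholin-4-yl. Methylamino or dimethylamino there, or a nitrile or carboxylic acid in place of the carbamoyl, would help separate these possibilities.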